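Amide-to-amine exchange on the fused core: compound 4

A few compounds are considered here, and "the series" means these few. Any claim that something is new, unique, unknown or untested is made for them only; others in the source may bear on it.

The series shares the core of compound 1 `CN1CCN(CC(=O)N2CC3C(c4ccccc4)CC(N(C)C)(CC3c3ccccc3)C2)CC1`, which in an ADME assay on L6 cells (Rattus norvegicus) for cytotoxicity, read by resazurin assay, with a stated time of 72 h (a lower number here means a stronger inhibitor, a higher number a weaker inhibitor), gives 9250 nM. Compound 2 `CN1CCN(CCC(=O)N2CC3C(c4ccccc4)CC(N(C)C)(CC3c3ccccc3)C2)CC1` gives 13000 nM in this assay, and compound 3 `CCN(CC)CCC(=O)N1CC2C(c3ccccc3)CC(N(C)C)(CC2c2ccccc2)C1` gives 15400 nM. Compound 2 stands second highest of the three numbers, nearest to compound 3 and furthest from compound 1, both within the scatter. The measured steps are all small: a 1.4-fold higher number from compound 1 to compound 2 (0.15 log units; within the scatter), a 1.7-fold higher number from compound 1 to compound 3 (0.22 log units; within the scatter) and a 1.2-fold higher number from compound 2 to compound 3 (0.07 log units; within the scatter). Compound 4 `CCN(CC)CCCN1CC2C(c3ccccc3)CC(N(C)C)(CC2c2ccccc2)C1` is not yet measured; it differs from compound 2 by 3-(diethylamino)propyl in place of (2-(4-methylpiperazin-1-yl)ethyl)carbonyl on an amine nitrogen in a ring. Among the compounds with values here, no measured step removes the carbonyl or changes what sits on the amine nitrogen in the ring beyond the amide tail, so the three steps bear on this change only in showing that exchanging amine tails among compounds 1, 2 and 3 left every number within the scatter. On that basis no step beyond the scatter is expected, but the change is larger than any measured one and the range must be wide. Compound 4 is therefore estimated at 8000 nM, with a range from 2500 nM to 25000 nM, an expected step of a 1.6-fold lower number from compound 2 to compound 4 (0.21 log units; within the scatter).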

Compound 4, half-maximal inhibitory concentration: 3270 nM
Compound 4: middle estimate off by 2.4-fold (0.39 log units), on the high side; low and high end bracket the measured number.
By their numbers in this assay, from the lowest: compound 4; then compounds 1, 2 and 3 (each within the scatter of the next).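

Within the data shown here, replacing the amide tail with 3-(diethylamino)propyl on the amine nitrogen in the ring is the first change to move the number in this assay beyond the scatter, with a 4.0-fold lower number from compound 2 to compound 4 (0.60 log units; beyond the scatter), a 4.7-fold lower number from compound 3 to compound 4 (0.67 log units; beyond the scatter) and a 2.8-fold lower number from compound 1 to compound 4 (0.45 log units; beyond the scatter). All three steps run towards a lower number, so changes at the carbonyl of this tail count for more here than the exchanges of amine tails among compounds 1, 2 and 3. The step to compound 4 from compound 3 is the most direct reading, since the diethylamino end stays and the carbonyl goes; no measurement here accounts for the shift.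

Going by these compounds, whether a 4-methylpiperazin-1-yl end on the same carbonyl-free chain gives a similar number remains open. So does the effect of a morpholine end or a longer chain at this ring nitrogen.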